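The compounds below may be only part of what the source reports. "The series", "measured", "known", "first", "only" and "open" are said of these compounds alone.

Three close relatives share one core and differ only in the aryl group attached to the carbon with a double bond to nitrogen. In a functional assay on HCT-116 cells (Homo sapiens) for inhibition, read by sulforhodamine B assay, with a stated time of 72 h (on this read-out higher numbers stand for weaker inhibition and lower numbers for stronger inhibition), compound 1 `COc1ccc2cc(C(C)c3nnc4n3N=C(c3ccc([N+](=O)[O-])cc3)CS4)ccc2c1` gives 15100 nM. Compound 2 `COc1ccc2cc(C(C)c3nnc4n3N=C(c3ccc(OC(F)(F)F)cc3)CS4)ccc2c1` gives 11700 nM. Compound 3 `COc1ccc2cc(C(C)c3nnc4n3N=C(c3ccc(Cl)cc3Cl)CS4)ccc2c1` gives 14000 nM. Compound 3 stands close to both companions, since a 1.1-fold lower number from compound 1 to compound 3 (0.03 log units; within the scatter) and a 1.2-fold higher number from compound 2 to compound 3 (0.08 log units; within the scatter) each lie within the scatter, as does a 1.3-fold lower number from compound 1 to compound 2 (0.11 log units; within the scatter). Compound 4 `COc1ccc2cc(C(C)c3nnc4n3N=C(c3ccc(F)cc3)CS4)ccc2c1` carries 4-fluorophenyl in place of 2,4-dichlorophenyl on a carbon with a double bond to nitrogen. The steps that already swapped the aryl group at this position, a 1.1-fold lower number from compound 1 to compound 3 (0.03 log units; within the scatter) and a 1.2-fold higher number from compound 2 to compound 3 (0.08 log units; within the scatter), moved nothing beyond the scatter, so in this assay a step of a 1.1-fold lower number from compound 3 to compound 4 (0.03 log units; within the scatter) is expected, with no change beyond the scatter. Compound 4 is therefore estimated at 13000 nM, likely between 6000 nM and 28000 nM.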

Compound 4, half-maximal inhibitory concentration: 13100 nM
Compound 4: the middle estimate sits 1.0-fold (0.00 log units) below what was measured; low and high end bracket the measured number.
By their numbers in this assay, from the lowest: compounds 2, 4, 3 and 1 (each within the scatter of the next).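

In this assay, the 4-fluorophenyl group, with a single fluorine as its only substituent, reads like the more heavily substituted aryl groups: the swap for 2,4-dichlorophenyl gives (a 1.1-fold lower number from compound 3 to compound 4 (0.03 log units; within the scatter)), the swap for the trifluoromethoxy group gives (a 1.1-fold higher number from compound 2 to compound 4 (0.05 log units; within the scatter)), and the swap for the nitro group gives (a 1.2-fold lower number from compound 1 to compound 4 (0.06 log units; within the scatter)). All four aryl groups at this carbon therefore sit within the scatter of one another. As far as these compounds go, whether an amine, a carboxylic acid or a longer chain in place of the aryl ring would move the number remains open. No measurement here explains why these aryl groups read alike.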